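Oxime ether variation on the diaryl sulfide series

The source may hold more compounds than are shown below. What is called first, only, known or untested is meant among the compounds shown, and "the series" means these compounds.

Measured so far:
- compound 1, `C/C(=N\OCc1ccncc1)c1ccc(Sc2cc(F)cc(C3CCOCC3)c2)cc1`: 300 nM
- compound 2, `C/C(=N\O)c1ccccc1Sc1cc(F)cc(C2CCOCC2)c1`: > 10000 nM
- compound 3, `CO[C@]1(c2cnc(Sc3ccc(/C(C)=N/O)cc3)s2)CCO[C@@H](C)C1`: 40 nM

In a functional assay (blood) for inhibition, with Homo sapiens as the target (a lower number here means a stronger inhibitor, a higher number a weaker inhibitor), compound 1 gives 300 nM, the higher of the two numbers available, with compound 3 at 40 nM lying a clear distance beyond the scatter. Compound 2 returns only a limit of the assay, > 10000 nM, and one of the three values shown sits at the limit of > 10000 nM in this assay, at which 1 of the 3 values shown sits.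

The next compound, compound 4 `C/C(=N\OC(C)C)c1ccc(Sc2cc(F)cc(C3CCOCC3)c2)cc1`, differs from compound 1 only at the oxygen of the oxime: isopropyl in place of (pyridin-4-yl)methyl on an oxygen. Within the data shown here, no two measured compounds differ by a single change, so no step is available to anchor this one. The oxygen substituent has not been varied among the measured compounds, and the change is a shrinking of the group to a small alkyl. A modest shift is expected, with direction uncertain, so the expected step of a 1.5-fold higher number from compound 1 to compound 4 (0.18 log units; within the scatter) lies near the edge of the scatter. For compound 4 in this assay the estimate is 450 nM, within a range from 120 nM to 1800 nM.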

Compound 4, half-maximal inhibitory concentration: 920 nM
Beside the measured number, compound 4's estimate is 2.0-fold (0.31 log units) below it; measured number inside the range.
By their numbers in this assay, from the lowest: compound 3; then compound 1; then compound 4. At a limit, above all of these: compound 2.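

The oxygen of the oxime now has one readable step in this assay: isopropyl in place of (pyridin-4-yl)methyl gives a 3.1-fold higher number from compound 1 to compound 4 (0.49 log units; beyond the scatter) and shows that the group at this position is not indifferent. The pair favours (pyridin-4-yl)methyl, yet the change takes away the aromatic ring, the ring nitrogen and the hydrogen-bond acceptor together, and this single step cannot separate them. Among these compounds, nothing measured so far accounts for the step.

A benzyl group on the same oxygen would show whether the ring nitrogen matters, and a longer chain ending in an amine would test a different kind of group. Also open, as far as these compounds go, is how the free oxime behaves on the core of compound 1, as compound 2 and compound 3 carry it but differ from compound 1 in more than one place.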